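Nitro to methylcarbamoyl on the benzylamine ring

A few compounds are considered here, and "the series" means these few. Any claim that something is new, unique, unknown or untested is made for them only; others in the source may bear on it.

Compound 1 `O=[N+]([O-])c1ccccc1CNc1cc(C(F)(F)F)cc2[nH]ncc12` and compound 2 `O=[N+]([O-])c1cccc(CNc2cc(C(F)(F)F)cc3[nH]ncc23)c1` share one core and differ only in where the nitro sits. In an assay for inhibition of Tryptophan 2,3-dioxygenase (Homo sapiens), with stated times of 10 min and 60 min, tested at 100 uM (on this read-out higher numbers stand for a stronger effect at the one concentration tested and lower numbers for a weaker effect), compound 1 gives 95%, and compound 2 gives 82%, the lower of the two numbers, with compound 1 standing above it by more than the usual scatter. Compound 3 `CNC(=O)c1cccc(CNc2cc(C(F)(F)F)cc3[nH]ncc23)c1` carries methylcarbamoyl in place of nitro on an aromatic carbon. Within the data shown here, no measured pair shows this change, so the step is expected to be a modest loss, a number 22 percentage points lower from compound 2 to compound 3 (beyond the scatter), beyond the scatter but leaving clear inhibition. Compound 3 is estimated at 60% in this assay, within 25% to 90%.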

Compound 3, a percentage reported as inhibition, at one concentration (the size of the read-out at that concentration, not a potency): 91%
Beside the measured number, compound 3's estimate is 31 percentage points below it; the measured number lies above the stated range.
By their numbers in this assay, from the lowest: compounds 2, 3 and 1 (each within the scatter of the next, the first and the last beyond it).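

In this assay, methylcarbamoyl in place of nitro on an aromatic carbon gives a number 9 percentage points higher from compound 2 to compound 3 (within the scatter), so the two groups cannot be told apart on this read-out. At this place, inhibition therefore does not depend on the nitro, and the change brings in a hydrogen-bond donor without a readable loss. No measurement at hand accounts for this tolerance.

On these data alone, it remains open how a carboxylic acid, an amine or a longer chain on the amide nitrogen would read here. Also open, as far as these compounds go, is how methylcarbamoyl would read where compound 1 carries its nitro.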